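Methyl on a Phenol Oxygen in Two Related Cores

The source may report more compounds than this note shows. Statements on the series, on what has been measured and on what is new or still open speak of the compounds shown alone.

Compound 1 `COc1ccc(/C=C2\Cc3ccccc3/C(=C\c3ccc([N+](=O)[O-])cc3)C2=O)cc1` and compound 2 `O=C1/C(=C/c2ccc(O)cc2)Cc2ccccc2/C1=C\c1ccc([N+](=O)[O-])cc1` share one core, while compound 3 `O=C1/C(=C/c2ccc(O)cc2)CCC/C1=C\c1ccc([N+](=O)[O-])cc1` and compound 4 `COc1ccc(/C=C2\CCC/C(=C\c3ccc([N+](=O)[O-])cc3)C2=O)cc1` share another; the difference between the two cores is not broken down here. In a functional assay on HSC-2 cells (Homo sapiens) for cytotoxicity (on this read-out higher numbers stand for lower toxicity in this test and lower numbers for higher toxicity in this test), compound 2 gives 5200 nM, compound 1 gives 11000 nM and compound 3 gives 8100 nM. Compound 1 differs from compound 2 by methyl in place of hydrogen on an oxygen on an aromatic ring, and that step was a 2.1-fold higher number from compound 2 to compound 1 (0.33 log units; beyond the scatter). Compound 4 differs from compound 3 by the same change, (methyl in place of hydrogen on an oxygen on an aromatic ring), at the same kind of place. From compound 3 a step of similar size is expected, a 2.1-fold higher number from compound 3 to compound 4 (0.32 log units; beyond the scatter). For the measured compounds named here, this expectation rests on compound 2 and compound 1, because their single change gave a 2.1-fold higher number from compound 2 to compound 1 (0.33 log units; beyond the scatter). Compound 4 is therefore estimated at 17000 nM, most likely between 8000 nM and 36000 nM.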

Compound 4, half-maximal cytotoxic concentration: > 400000 nM
Compound 4 was reported as a limit; the forecaster's own chance of this, stated with the estimate: 10%; middle value at least 23-fold (1.37 log units) from the limit.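

In this assay, the change from hydroxy to methoxy gives an at least 49-fold higher number from compound 3 to compound 4 (1.69 log units; beyond the scatter). The direction matches on both cores, but the size of the step does not carry over from one core to the other: the same change on two cores in this assay, a 2.1-fold higher number (0.33 log units; beyond the scatter) from compound 2 to compound 1 and an at least 49-fold higher number (1.69 log units; beyond the scatter) from compound 3 to compound 4, at least 23-fold (1.36 log units) apart, beyond the scatter of two such steps

On these data alone, compound 4 stands at > 400000 nM, which is a limit of the assay and not a number, so its true value stays unknown, and these two pairs do not show which feature of the cores sets the gap.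

The compounds shown leave open how a longer chain such as ethyl or propyl on this oxygen would behave on each core. They also leave open whether an amine in place of the hydroxy would show the same split between the two cores.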